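The source may hold more compounds than are shown below. What is called first, only, known or untested is meant among the compounds shown, and "the series" means these compounds.

Compound 1 `COc1ccc(OS(=O)(=O)c2ccc(N3CCN(C)C3=O)cc2)cc1OC` and compound 2 `COc1cc(OS(=O)(=O)c2ccc(N3CCN(C)C3=O)cc2)cc(OC)c1OC` share one core and differ in a single place: methoxy in place of hydrogen on an aromatic carbon. In a functional assay on MCF7 cells (Homo sapiens) for antiproliferative activity, read by sulforhodamine B assay, with a stated time of 48 h (a lower number here means a stronger inhibitor, a higher number a weaker inhibitor), compound 1 gives 12000 nM, and compound 2 gives 120 nM, so that added methoxy produced a 100-fold lower number from compound 1 to compound 2 (2.00 log units; beyond the scatter). Compound 3 `CCN1CCN(c2ccc(S(=O)(=O)Oc3cccc(OC)c3)cc2)C1=O` is built on another core; the difference between the two cores is not broken down here. In this assay compound 3 gives 14000 nM. Compound 4 `CCN1CCN(c2ccc(S(=O)(=O)Oc3cc(OC)cc(OC)c3)cc2)C1=O` awaits measurement and differs from compound 3 by the same kind of change, (methoxy in place of hydrogen on an aromatic carbon); in compound 2 the entering group was also ortho to a methoxy group, which is not so here. Because the earlier methoxy gave a 100-fold lower number from compound 1 to compound 2 (2.00 log units; beyond the scatter) with that neighbour present, and it is absent now, a smaller step is expected, a 4.7-fold lower number from compound 3 to compound 4 (0.67 log units; beyond the scatter). Compound 4 is estimated at 3000 nM, most likely between 300 nM and 15000 nM.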

Compound 4, half-maximal inhibitory concentration: 3500 nM
Beside the measured number, compound 4's estimate is 1.2-fold (0.07 log units) below it; low and high end bracket the measured number.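

On the second core, methoxy in place of hydrogen on an aromatic carbon again lowers the number in this assay (a 4.0-fold lower number from compound 3 to compound 4 (0.60 log units; beyond the scatter)), so the direction of the change carries over in these two pairs. Two pairs cannot show what sets the size of the step, since the core and the surroundings of the entering methoxy differ at once between them. The size itself does not carry over: the same change on two cores in this assay, a 100-fold lower number (2.00 log units; beyond the scatter) from compound 1 to compound 2 and a 4.0-fold lower number (0.60 log units; beyond the scatter) from compound 3 to compound 4, 25-fold (1.40 log units) apart, beyond the scatter of two such steps

Open, on these data alone, is whether the core of compound 3 bearing the three methoxy groups of compound 2 would reach the low number of compound 2. Also open, as far as these compounds go, is whether an ethoxy group, a hydroxyl or an amine in place of the entering methoxy would lower the number too.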